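A few compounds are considered here, and "the series" means these few. Any claim that something is new, unique, unknown or untested is made for them only; others in the source may bear on it.

Compound 1, `CC1CCN(c2ccc(Nc3ncc4c(n3)N(C3CCCC3)CC(=O)N4C)cc2)CC1`: in a functional assay on HeLa cells (Homo sapiens) for inhibition, read by MTT assay, with a stated time of 48 h (a lower number here means a stronger inhibitor, a higher number a weaker inhibitor), compound 1 gives only a limit, > 30000 nM.
Compound 2, `CN1CCN(c2ccc(Nc3ncc4c(n3)N(C3CCCC3)CC(=O)N4C)nc2)CC1`: in this assay compound 2 gives 13100 nM.
Compound 3, `CCN1C(=O)CN(C2CCCC2)c2nc(Nc3ccc(N4CCC(C)CC4)cc3)ncc21`: in this assay compound 3 gives only a limit, > 30000 nM.

Compound 3 differs from compound 1 by methyl in place of hydrogen on a saturated chain carbon bound to an amide-type nitrogen in a ring. The step that the two limits leave unreadable from compound 1 to compound 3 cannot be sized because of the limit of > 30000 nM in this assay, at which 2 of the 3 values shown sit. Compound 2 has a different core from compound 1; the difference between the two cores is not broken down here. For the measured compounds named here, compound 4, `CCN1C(=O)CN(C2CCCC2)c2nc(Nc3ccc(N4CCN(C)CC4)cn3)ncc21`, is not yet measured; it differs from compound 2 by methyl in place of hydrogen on a saturated chain carbon bound to an amide-type nitrogen in a ring, the same change as the one from compound 1 to compound 3. With the measured step unreadable, the expectation rests on compound 2 alone, whose value in this assay is 13100 nM. Compound 4 is therefore expected to give about 15000 nM, between 6000 nM and 40000 nM. The step of a 1.1-fold higher number from compound 2 to compound 4 (0.06 log units; within the scatter) that this estimate implies is expected to be small.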

Compound 4, half-maximal inhibitory concentration: 29100 nM
Beside the measured number, compound 4's estimate is 1.9-fold (0.29 log units) below it; the range from low to high includes it.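

In this assay, methyl in place of hydrogen on a saturated chain carbon bound to an amide-type nitrogen in a ring gives a 2.2-fold higher number from compound 2 to compound 4 (0.35 log units; beyond the scatter), so on this core the change weakens inhibition modestly. For the compounds shown here, on the core of compound 1 the same change cannot be read, because compound 1 and compound 3 both give only a limit of the assay: the limit of > 30000 nM in this assay, at which 2 of the 4 values shown sit. The one readable step therefore describes the change on a single core and does not show that it carries over from one core to another.

The compounds shown leave open how a longer chain such as propyl, or an amine or a carboxylic acid, would read in place of the ethyl in this assay. They also leave open whether the methyl to ethyl change would give a similar step on a further core with values clear of the limit.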